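The compounds below may be only part of what the source reports. "The series", "measured", "known", "first", "only" and "open" are said of these compounds alone.

Three nitrofuran chalcones have been tested in an ADME assay on THP-1 cells (Homo sapiens) for cytotoxicity, read by resazurin assay, with a stated time of 72 h; a higher number here means that more compound is tolerated, a lower number that less compound is tolerated. Compound 1 `O=C(/C=C/c1ccc([N+](=O)[O-])o1)c1ccc(I)cc1` gives 49500 nM; compound 2 `Cc1ccccc1C(=O)/C=C/c1ccc([N+](=O)[O-])o1` gives 27900 nM; compound 3 `CSc1ccc(C(=O)/C=C/c2ccc([N+](=O)[O-])o2)cc1` gives 13100 nM. One pair differs in a single place: the change a 3.8-fold lower number from compound 1 to compound 3 (0.58 log units; beyond the scatter). Compound 3 thus stands lowest of the three numbers in this assay, with compound 2 nearest and compound 1 furthest, both beyond the scatter.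

Compound 4 `CCCCc1ccc(C(=O)/C=C/c2ccc([N+](=O)[O-])o2)cc1` has not yet been measured. It differs from compound 3 as follows: butyl in place of methylsulfanyl on an aromatic carbon. Among the compounds with values here, only the step from compound 1 to compound 3 touches the same position, and it shows that exchanging the group there can move this assay by a modest amount; compound 2 differs at another place and does not bear directly on the change. Within the data shown here, no measured pair swaps a methylsulfanyl for a butyl, so the direction is uncertain. The author expects a step of similar size or smaller, a 1.3-fold lower number from compound 3 to compound 4 (0.12 log units; within the scatter), that may well stay within the scatter. The estimate for compound 4 in this assay is therefore 10000 nM, within a range from 4000 nM to 30000 nM.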

Compound 4, half-maximal cytotoxic concentration: 48700 nM
Compound 4: middle estimate off by 4.9-fold (0.69 log units), on the low side; measured number above the stated range.
By their numbers in this assay, from the lowest: compound 3; then compounds 2, 4 and 1 (each within the scatter of the next).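

In this assay this position on the six-membered aromatic ring, para to a large group, proves able to move the number in both directions: a 3.8-fold lower number from compound 1 to compound 3 (0.58 log units; beyond the scatter) is now answered by a 3.7-fold higher number from compound 3 to compound 4 (0.57 log units; beyond the scatter) when butyl replaces methylsulfanyl. The further comparison gives a 1.0-fold lower number from compound 1 to compound 4 (0.01 log units; within the scatter), so iodo and butyl cannot be told apart here, and among these three groups methylsulfanyl alone stands apart, with the lower number of compound 3 resting on that single compound. Nothing measured here accounts for why methylsulfanyl differs from the other two groups, so the shift remains an observation without an explanation.

The compounds shown leave open whether the lower number is specific to methylsulfanyl or would also appear with another small group carrying a heteroatom, such as methoxy, an amine or a longer sulfur-bearing chain like ethylsulfanyl. They also leave open how a carboxylic acid or a chain longer than butyl at this position would behave, and whether the tolerance seen with butyl and iodo would persist.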